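From Hydroxy to 2-Hydroxyethyl on the Aromatic Ring

The source may report more compounds than this note shows. Statements on the series, on what has been measured and on what is new or still open speak of the compounds shown alone.

In a functional assay (mast cells) for inhibition, with Rattus norvegicus as the target (a lower number here means that less compound is needed, a higher number that more compound is needed for the effect), compound 2 (`CC1CC/C(=N\Nc2ccccc2O)c2ncc(C(=O)O)c(=O)n21`) gives 208000 nM as the highest of three measured numbers. Compound 1 (`CC1CC/C(=N\Nc2ccccc2F)c2ncc(C(=O)O)c(=O)n21`) gives 1200 nM and compound 3 (`Cc1ccc(N/N=C2\CCC(C)n3c2ncc(C(=O)O)c3=O)cc1`) gives 280 nM in the same test. Compound 4 (`CC1CC/C(=N\Nc2ccccc2CCO)c2ncc(C(=O)O)c(=O)n21`) has 2-hydroxyethyl in place of hydroxy on an aromatic carbon. Two large steps bear on this change: a 170-fold higher number from compound 1 to compound 2 (2.24 log units; beyond the scatter) with hydroxy entering for fluoro, and a 740-fold lower number from compound 2 to compound 3 (2.87 log units; beyond the scatter) with hydroxy gone. Within the data shown here, no measured compound carries the 2-hydroxyethyl group, and it retains a hydroxy at its end, so a large step to a lower number is expected, though smaller than either of those. The estimate means a 35-fold lower number from compound 2 to compound 4 (1.54 log units; beyond the scatter) as the expected step. For compound 4 the expected value is 6000 nM (estimated range 1000 nM to 40000 nM).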

Compound 4, half-maximal effective concentration: 330000 nM
Estimate against measurement, compound 4: 55-fold (1.74 log units) below; the measured number lies above the stated range.
By their numbers in this assay, from the lowest: compound 3; then compound 1; then compounds 2 and 4 (each within the scatter of the next).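

In this assay, carrying the hydroxy at the end of a 2-hydroxyethyl group instead of directly on the aromatic carbon, ortho to a large group, gives a 1.6-fold higher number from compound 2 to compound 4 (0.20 log units; within the scatter). Against fluoro at the same place, the 2-hydroxyethyl group gives a 280-fold higher number from compound 1 to compound 4 (2.44 log units; beyond the scatter), so both hydroxy-bearing groups lie far on the high side of compound 1. No measurement shown here accounts for this result. On these data alone, it remains open whether a methoxy, an amine or a carboxylic acid at this place would stand with fluoro or with the hydroxy-bearing groups. As far as these compounds go, a longer chain ending in hydroxy is equally open.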